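The source may hold more compounds than are shown below. What is called first, only, known or untested is meant among the compounds shown, and "the series" means these compounds.

Measured compounds:
Compound 1 `NC(=O)c1c(NC(=O)c2ccccc2Cl)sc2c1CCN(C(=S)Nc1ccccc1F)C2`: 4970 nM
Compound 2 `NC(=O)c1c(NC(=O)c2ccccc2Cl)sc2c1CCN(C(=S)Nc1ccccc1Br)C2`: 9090 nM
Compound 3 `NC(=O)c1c(NC(=O)c2ccccc2Br)sc2c1CCN(C(=S)Nc1ccccc1F)C2`: only a limit is known

All three were tested in a functional assay on HL-60 cells (Homo sapiens) for antiproliferative activity, with a stated time of 24 h; a lower number here means a stronger inhibitor, a higher number a weaker inhibitor. Compound 1 gives 4970 nM and compound 2 gives 9090 nM. For compound 3 the assay reports only a limit, > 50000 nM, and no number.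

Compound 2 differs from compound 1 by a single change, (bromo in place of fluoro on an aromatic carbon), and this change made a step of a 1.8-fold higher number from compound 1 to compound 2 (0.26 log units; within the scatter). The two cores differ in another place: bromo in place of chloro on an aromatic carbon. That difference made a step of an at least 10-fold higher number from compound 1 to compound 3 (1.00 log units; beyond the scatter), its size bounded only by the limit of > 50000 nM in this assay, at which 1 of the 3 values shown sits.

Compound 4 `NC(=O)c1c(NC(=O)c2ccccc2Br)sc2c1CCN(C(=S)Nc1ccccc1Br)C2` has not yet been measured in this assay. It is reached from compound 3 by bromo in place of fluoro on an aromatic carbon, the same change that separates compound 2 from compound 1. Because that earlier step was a 1.8-fold higher number from compound 1 to compound 2 (0.26 log units; within the scatter), compound 4 is expected to move from compound 3 by a step that the limit leaves unreadable from compound 3 to compound 4, so that the assay is expected to report a limit again. The estimate for compound 4 is therefore 90000 nM, with a range from 40000 nM to 250000 nM.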

Compound 4, half-maximal inhibitory concentration: 17600 nM
Compound 4: middle estimate off by 5.1-fold (0.71 log units), on the high side, and the stated range ends above it.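

In this assay, bromo in place of fluoro did not behave the same way on the two cores: here it gave an at least 2.8-fold lower number from compound 3 to compound 4 (0.45 log units; beyond the scatter), and this step differs from the earlier one: the same change on two cores in this assay, a 1.8-fold higher number (0.26 log units; within the scatter) from compound 1 to compound 2 and an at least 2.8-fold lower number (0.45 log units; beyond the scatter) from compound 3 to compound 4, at least 5.1-fold (0.71 log units) apart, beyond the scatter of two such steps. Bromo in place of chloro gave a 1.9-fold higher number from compound 2 to compound 4 (0.29 log units; within the scatter), which also differs from its earlier counterpart on the other core: the same change on two cores in this assay, an at least 10-fold higher number (1.00 log units; beyond the scatter) from compound 1 to compound 3 and a 1.9-fold higher number (0.29 log units; within the scatter) from compound 2 to compound 4, at least 5.1-fold (0.71 log units) apart, beyond the scatter of two such steps. Within these four compounds, therefore, neither change carries over as a fixed step from one core to the other, but the true size of either gap remains unknown and the data give no reason for it, for compound 3 is known only through a limit: the limit of > 50000 nM in this assay, at which 1 of the 4 values shown sits.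

The compounds shown leave open whether this dependence on the core extends to an iodo, methyl or methoxy group in place of the halogen on either aromatic ring. They also leave open whether it persists when a carbonyl takes the place of the thiocarbonyl.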